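The source may report more compounds than this note shows. Statements on the series, on what has been measured and on what is new or still open speak of the compounds shown alone.

Measured so far:
compound 1 `O=c1c2cnn(-c3ccc(F)cc3)c2ncn1CC1(O)CCN(Cc2cccnc2)CC1` — "not determined" (no result reported) in an assay on Sf21 cells for inhibition of ubiquitin carboxyl-terminal hydrolase 7 (Homo sapiens), read by spectrophotometry, with stated times of 30 min and 2 h; on this read-out higher numbers stand for weaker inhibition and lower numbers for stronger inhibition
compound 2 `O=c1c2cnn(-c3ccc(F)cc3)c2ncn1CC1(O)CCN(Cc2ccccc2F)CC1` — 9800 nM

In this assay, within the data shown here, compound 2 gives 9800 nM, the only number in the set. Compound 1 has no result there. Compound 3 `O=c1c2cnn(-c3ccc(F)cc3)c2ncn1CC1(O)CCN(Cc2ccccc2Br)CC1` differs from compound 2 by bromo in place of fluoro on an aromatic carbon. Among the measured compounds shown here, no step between measured compounds is available, so the weight of this change is not calibrated; a step no larger than the scatter is expected, in either direction. Compound 3 is expected to give 8000 nM (range 3000 nM to 25000 nM), which means an expected step of a 1.2-fold lower number from compound 2 to compound 3 (0.09 log units; within the scatter) that stays within the scatter.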

Compound 3, half-maximal inhibitory concentration: 3100 nM
For compound 3 the middle estimate is 2.6-fold (0.41 log units) above the measured one, within the range that was stated.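

In this assay, among these compounds, going from 2-fluorobenzyl to 2-bromobenzyl gives a 3.2-fold lower number from compound 2 to compound 3 (0.50 log units; beyond the scatter) and supplies the first calibrated step. This place on the aromatic ring, ortho to a large group, therefore responds measurably to the identity of the halogen, although a single pair sets no trend. No measured evidence available here bears on the origin of this step.

Any step involving compound 1 cannot be read, as it has no number. Still open, on these data alone, is how chloro, methoxy or an amine would read at this same place.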